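Amino in place of trifluoromethyl on a hydrazone-free core

A few compounds are considered here, and "the series" means these few. Any claim that something is new, unique, unknown or untested is made for them only; others in the source may bear on it.

Compound 2 `FC(F)(F)c1cccc(CNc2cc(C(F)(F)F)cc3[nH]ncc23)c1` is one of three measured compounds. In an assay for inhibition of Indoleamine 2,3-dioxygenase 1 (Homo sapiens), with stated times of 10 min and 60 min (a higher number here means a weaker inhibitor, a lower number a stronger inhibitor), compound 2 gives only a limit of the assay, > 100000 nM, and no number. Compound 1 `O=C1NCc2c(NCc3ccccc3[N+](=O)[O-])cccc21` likewise gives only a limit in this assay, > 100000 nM. Compound 3 `O=[N+]([O-])c1ccc(Cl)cc1CNc1cc(C(F)(F)F)cc2[nH]ncc12` gives a number in this assay, 37700 nM. Compound 2 therefore stands at the limit of > 100000 nM in this assay, at which 2 of the 3 values shown sit, together with compound 1, while compound 3 alone yields a measured value.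

Compound 4 `Nc1cccc(CNc2cc(C(F)(F)F)cc3[nH]ncc23)c1` has not yet been measured. It differs from compound 2 in one place: amino in place of trifluoromethyl on an aromatic carbon. Going by the values given here, no step between measured compounds that differ in one place is on hand, so the size of this change in this assay cannot be read from a measured pair. A move beyond the scatter in either direction is possible, but there is no ground to expect one.

Compound 4 is expected to come out near 100000 nM, within 30000 nM to 300000 nM. The step from compound 2 to compound 4 is estimated as a number no higher from compound 2 to compound 4 (the limit leaves the size open), with a fair chance that only a limit is reported again.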

Compound 4, half-maximal inhibitory concentration: > 100000 nM
Compound 4 ended at the assay's limit; the forecaster's own chance of this, stated with the estimate: 60%; the middle value lies on the limit itself.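

In this assay compound 4 gives only a limit, > 100000 nM. Going by these compounds alone, compound 2 likewise gives only a limit, > 100000 nM, so no step between compound 2 and compound 4 can be read. The compounds shown leave open whether amino in place of trifluoromethyl on an aromatic carbon changes inhibition at all.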